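Chloro to fluoro on the shared core: compound 3

The source may report more compounds than this note shows. Statements on the series, on what has been measured and on what is new or still open speak of the compounds shown alone.

Measured so far:
compound 1, `COc1ccc(Cc2nnc3sc(-c4ccnc(Cl)c4)nn23)cc1OC`, 24.2%
compound 2, `Cc1occc1-c1nnc2sc(-c3ccnc(Cl)c3)nn12`, 27.1%

Both compounds were read in a functional assay on the whole organism (strain Wistar Albino) for inhibition, with Rattus norvegicus as the target, read by paw edema, with a stated time of 4 h, at a dose of 20 mg/kg; a lower number here means less inhibition, a higher number more inhibition at the dose given (going by the name of the read-out). In this assay compound 1 gives 24.2%, and compound 2 gives 27.1%. The two numbers lie within the usual scatter of each other, so nothing separates compound 1 from compound 2 on these data; compound 1 stands at one of two indistinguishable points.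

Compound 3, `COc1ccc(Cc2nnc3sc(-c4ccnc(F)c4)nn23)cc1OC`, has not been measured. It differs from compound 1 in one place: fluoro in place of chloro on an aromatic carbon. One halogen of one heavy atom leaves and another halogen of one heavy atom enters, with no change in ring count, donors, acceptors or charge. Going by the values given here, no measured pair carries such a change, so there is no step to lean on.

Given the size of the change, the step of a number 0.2 percentage points lower from compound 1 to compound 3 (within the scatter) is expected to stay within the scatter, in no clear direction. Compound 3 is therefore estimated at 24%, with a range from 14% to 34%.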

Compound 3, a percentage reported as inhibition, in the whole organism at one dose (the size of the read-out at that dose, not a potency): 21.5%
Estimate against measurement, compound 3: 2.5 percentage points above, and the stated range covers the measured number.
By their numbers in this assay, from the lowest: compounds 3, 1 and 2 (each within the scatter of the next).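

In this assay, going by these compounds alone, the exchange of chloro for fluoro on the aromatic carbon next to the ring nitrogen gives a number 2.7 percentage points lower from compound 1 to compound 3 (within the scatter) and is the first step in one place that the series offers. For this one pair, the change from 2-chloropyridin-4-yl to 2-fluoropyridin-4-yl produces no shift that the read-out separates from repeat scatter: compound 1 at 24.2% and compound 3 at 21.5% remain indistinguishable at this dose. No accompanying measurement speaks to a cause.

The compounds shown leave open whether this carbon responds to anything other than a halogen: hydrogen, an amine, a methoxy group or a nitrile in the same place would test whether the read-out moves there at all. Also open, going by these compounds, is whether fluoro in place of chloro would read the same way on compound 2, since a single step on the core of compound 1 says nothing about how far it carries to another substituent at the far end of the shared core.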